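A pyridin-3-yl hydrazone variant in a weakly active series

The source may report more compounds than this note shows. Statements on the series, on what has been measured and on what is new or still open speak of the compounds shown alone.

Compound 2 `CC1CCC(=NNc2ccc(Cl)c(Cl)c2)c2ncc(C(=O)O)c(=O)n21` was examined in a functional assay on the whole organism with Rattus norvegicus as the target (on this read-out higher numbers stand for an effect only at larger amounts of compound and lower numbers for an effect already at smaller amounts), and gave only a limit: in this assay compound 2 shows > 100 umol/kg. For the measured compounds named here, its one measured neighbour, compound 1 `Cc1cc(C)cc(NN=C2CCC(C)n3c2ncc(C(=O)O)c3=O)c1`, likewise reached only a limit, giving > 320 umol/kg in this assay. Going by the values given here, the single measured step, a step that the two limits leave unreadable from compound 1 to compound 2, therefore cannot be read in size or direction; the two limits the limit of > 100 umol/kg in this assay, at which 1 of the 2 values shown sits, and the limit of > 320 umol/kg in this assay, at which 1 of the 2 values shown sits, are all the evidence at hand. Compound 3 `CC1CCC(=NNc2cccnc2)c2ncc(C(=O)O)c(=O)n21` is the next member of the set. Relative to compound 2 the change is pyridin-3-yl in place of 3,4-dichlorophenyl on an amine nitrogen. Among the compounds with values here, no measured step touches a change of this kind, and the step that does exist sets no size at all, so nothing in these numbers points to a direction in this assay. For compound 3 the step that the limit leaves unreadable from compound 2 to compound 3 is expected to stay within the scatter, and a reported limit rather than a number is the more probable outcome. On that basis compound 3 is estimated at 150 umol/kg, with a range from 40 umol/kg to 600 umol/kg.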

Compound 3, dose for 50% inhibition: > 320 umol/kg
Compound 3 ended at the assay's limit; the forecaster's own chance of this, stated with the estimate: 65%; at least 2.1-fold (0.32 log units) between middle value and limit.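

In this assay compound 3 gives > 320 umol/kg, a limit of the assay and not a number. For the compounds shown here, neither the step from compound 2 to compound 3 nor the one from compound 1 to compound 3 can be read. The compounds shown leave open whether pyridin-3-yl, 3,4-dichlorophenyl and 3,5-dimethylphenyl on the amine nitrogen differ at all in this assay.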